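The compounds below may be only part of what the source reports. "The series", "measured", "known", "first", "only" and "open" are said of these compounds alone.

Going by the values given here, in a functional assay on HeLa cells (Homo sapiens) for antiproliferative activity, read by MTT assay, with a stated time of 48 h (a higher number here means a weaker inhibitor of growth, a lower number a stronger inhibitor of growth), compound 2 `COC(=O)N1N=C(c2cccc(O)c2)CC1c1cc(OC)c(OC)c(OC)c1` gives 1970 nM as the only true number so far. Compound 1 `COc1cc(C2CC(c3ccccc3)=NN2C(=O)OCc2ccccc2)cc(OC)c1OC` also carries benzyloxycarbonyl, and its > 10000 nM is a limit of the assay, so a weaker value than that of compound 2 is expected once this group enters, although compound 1 differs elsewhere too. Compound 3 `COc1cc(C2CC(c3cccc(O)c3)=NN2C(=O)OCc2ccccc2)cc(OC)c1OC` differs from compound 2 by phenyl in place of hydrogen on a saturated chain carbon bound to an oxygen next to a carbonyl group and so has benzyloxycarbonyl in place of methoxycarbonyl. Among the compounds with values here, no measured step covers this change. The estimated 1.8-fold higher number from compound 2 to compound 3 (0.25 log units; within the scatter) is a modest weakening. Compound 3 is expected at 3500 nM within an estimated range of 900 nM to 10000 nM in this assay when measured.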

Compound 3, concentration for 50% growth inhibition: > 10000 nM
Compound 3 was reported as a limit; the forecaster's own chance of this, stated with the estimate: 25%; middle value at least 2.8-fold (0.45 log units) away from the limit.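

In this assay, the change from methoxycarbonyl to benzyloxycarbonyl gives an at least 5.0-fold higher number from compound 2 to compound 3 (0.70 log units; beyond the scatter), so with the hydroxy group present on both compounds, phenyl at this place weakens growth inhibition beyond the scatter. The value of compound 3 is a limit, so this step is a lower bound. The steps between compounds that both stand at the limit cannot be read: the limit of > 10000 nM in this assay, at which 2 of the 3 values shown sit.

The compounds shown leave open how an ethyl ester or a longer chain would behave at this place, and whether an amine there would keep the value of compound 2.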